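From 4-aminophenyl to 3-methoxyphenyl on a shared core

This account rests on a few compounds, and the source may have more. Where it says the series, first, only, none or still open, it means among the compounds named here.

Of the compounds shown here, two with the same core have been measured so far. In an ADME assay on cells (spleen, Mus musculus, strain C57BL/6) for inhibition, read by flow cytometry and propidium iodide staining, with a stated time of 24 h, at 37 degrees C (on this read-out lower numbers stand for an effect already at smaller amounts and higher numbers for an effect only at larger amounts of compound), compound 1 `CCC(O)Cc1cn(CC(=O)NCc2ccccc2)nn1` gives 630 uM. Compound 2 `Nc1ccc(-c2cn(CC(=O)NCc3ccccc3)nn2)cc1` gives 1240 uM, which lies within the usual scatter of the value for compound 1, so the numbers do not separate the two.

Compound 3 `COc1cccc(-c2cn(CC(=O)NCc3ccccc3)nn2)c1` keeps that core and has 3-methoxyphenyl in place of 4-aminophenyl on an aromatic carbon. Within the data shown here, no measured compound carries a 3-methoxyphenyl group, so the data cannot test this group directly. Among the measured compounds shown here, only one measured step bears on the change: replacing 2-hydroxybutyl with 4-aminophenyl on an aromatic carbon gave a 2.0-fold higher number from compound 1 to compound 2 (0.29 log units; within the scatter). That single step is thin evidence, but it offers no reason to expect a real shift when one group is exchanged for another here. No step beyond the scatter is therefore expected in this assay, and no firm direction can be given. The estimate is a 1.2-fold lower number from compound 2 to compound 3 (0.09 log units; within the scatter). For compound 3 the expected value is 1000 uM, with an estimated range from 400 uM to 2500 uM.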

Compound 3, concentration for half-maximal effect: 840 uM
Beside the measured number, compound 3's estimate is 1.2-fold (0.08 log units) above it; the measured number falls inside the stated range.
By their numbers in this assay, from the lowest: compounds 1, 3 and 2 (each within the scatter of the next).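

In this assay, this aromatic carbon has now carried three different groups, and the numbers do not separate any of them. Putting 3-methoxyphenyl in place of 4-aminophenyl gives a 1.5-fold lower number from compound 2 to compound 3 (0.17 log units; within the scatter) even though the entering group has 0 hydrogen-bond donors where the leaving group has 1, so on these numbers that difference in count comes with no step beyond the scatter. Putting 3-methoxyphenyl in place of the open chain 2-hydroxybutyl gives a 1.3-fold higher number from compound 1 to compound 3 (0.12 log units; within the scatter) and is also not separated, and no outside measurement is available to say why these three compounds sit so close together.

From the compounds shown here alone, it remains open whether any group at this position can move the number beyond the scatter, for example a carboxylic acid or a single methyl group in place of these larger groups. Going by these compounds, it is also open whether moving the methoxy group around the phenyl ring would matter, as a comparison of 3-methoxyphenyl with 4-methoxyphenyl could show.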